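Hydroxymethyl to isopropyl swap across two related cores

The source may hold more compounds than are shown below. What is called first, only, known or untested is meant among the compounds shown, and "the series" means these compounds.

Measured so far in an ADME assay on L1210 cells (Mus musculus) for cytotoxicity, with a stated time of 48 h; on this read-out lower numbers stand for stronger inhibition and higher numbers for weaker inhibition:
compound 1 `CC1=CCC[C@](C)(CC/C(C)=C/CC2=C(O)C(=O)C=C(N[C@@H](C(=O)O)C(C)C)C2=O)[C@@H]1C`: 3 ug/mL
compound 2 `CC1=CCC[C@](C)(CC/C(C)=C/CC2=C(O)C(=O)C=C(N[C@H](CO)C(=O)O)C2=O)[C@@H]1C`: limit, > 10 ug/mL
compound 3 `C=C1[C@H](C)CCC[C@]1(C)CC/C(C)=C/CC1=C(O)C(=O)C=C(N[C@@H](CO)C(=O)O)C1=O`: limit, > 10 ug/mL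

Compound 2 reaches only a limit of the assay, > 10 ug/mL. Compound 3 likewise reaches only a limit, > 10 ug/mL. The difference between the cores of compound 2 and compound 3 is not broken down here. Compound 1 carries isopropyl in place of hydroxymethyl on a saturated chain carbon bound to an amine nitrogen and a carbonyl carbon; the step is an at least 3.3-fold lower number from compound 2 to compound 1 (0.52 log units; beyond the scatter), open-ended since compound 2 sits at the limit of > 10 ug/mL in this assay, at which 2 of the 3 values shown sit. Compound 4 `C=C1[C@H](C)CCC[C@]1(C)CC/C(C)=C/CC1=C(O)C(=O)C=C(N[C@H](C(=O)O)C(C)C)C1=O` carries the same change on the core of compound 3: isopropyl in place of hydroxymethyl on a saturated chain carbon bound to an amine nitrogen and a carbonyl carbon.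

Compound 4 is expected to give 3 ug/mL in this assay, between 1.5 ug/mL and 8 ug/mL. That expectation amounts to an at least 3.3-fold lower number from compound 3 to compound 4 (0.52 log units; beyond the scatter) and rests on an at least 3.3-fold lower number from compound 2 to compound 1 (0.52 log units; beyond the scatter) together with the number reached by compound 1, 3 ug/mL.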

Compound 4, half-maximal inhibitory concentration: 4.4 ug/mL
The estimate for compound 4 lay 1.5-fold (0.17 log units) below the measured number; the measured number falls inside the stated range.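

In this assay the change from hydroxymethyl to isopropyl gives a lower number on both cores: an at least 2.2-fold lower number from compound 3 to compound 4 (0.35 log units; beyond the scatter), in the same direction as an at least 3.3-fold lower number from compound 2 to compound 1 (0.52 log units; beyond the scatter). Compound 3 sits at > 10 ug/mL, a limit of the assay and not a number. The two pairs show that the direction carries over between these two cores, but not that the size does: the same change on two cores in this assay, an at least 3.3-fold lower number (0.52 log units; beyond the scatter) from compound 2 to compound 1 and an at least 2.2-fold lower number (0.35 log units; beyond the scatter) from compound 3 to compound 4; the limit leaves it open whether they differ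

Open, going by these compounds, is whether the same change gives a lower number on any further core. Also open, on these data alone, is how a benzyl group or a longer chain ending in an amine would compare with isopropyl on a saturated chain carbon bound to an amine nitrogen and a carbonyl carbon.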